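The source may report more compounds than this note shows. Statements on the series, on what has been measured and on what is new or still open speak of the compounds shown alone.

Measured so far in a functional assay on NCI-H1299 cells (Homo sapiens) for antiproliferative activity, read by MTT assay, with a stated time of 48 h; a higher number here means a weaker inhibitor, a lower number a stronger inhibitor:

Compound 1 `CN1C(=O)C2(C(C#N)=C(N)Oc3cc4oc(-c5ccccc5)cc(=O)c4c(O)c32)c2cc(Cl)ccc21` — compound 1 gives 11200 nM
Compound 2 `CN1C(=O)C2(C(C#N)=C(N)Oc3cc4oc(-c5ccccc5)cc(=O)c4c(O)c32)c2cc(Br)ccc21` — compound 2 gives 7610 nM
Compound 3 `N#CC1=C(N)Oc2cc3oc(-c4ccccc4)cc(=O)c3c(O)c2C12C(=O)Nc1cc(Cl)ccc12` — compound 3 gives 16600 nM

Compound 1 and compound 2 share a core and differ only at one aromatic carbon, (bromo in place of chloro on an aromatic carbon). In this assay this gives a 1.5-fold lower number from compound 1 to compound 2 (0.17 log units; within the scatter). Compound 3 carries a different core; the difference between the core of compound 3 and the core of compound 1 is not broken down here. Compound 3 stands at the highest of the three numbers, within the scatter of compound 1 and beyond the scatter of compound 2.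

Compound 4 `N#CC1=C(N)Oc2cc3oc(-c4ccccc4)cc(=O)c3c(O)c2C12C(=O)Nc1cc(Br)ccc12` is not yet measured. It relates to compound 3 as compound 2 does to compound 1: bromo in place of chloro on an aromatic carbon, at the same place in the same words. For the measured compounds named here, the step is expected to be of the same kind and size, because the only measured instance of it is a 1.5-fold lower number from compound 1 to compound 2 (0.17 log units; within the scatter); the expected step is a 1.5-fold lower number from compound 3 to compound 4 (0.18 log units; within the scatter). On that basis compound 4 is expected at 11000 nM. The range expected for compound 4 runs from 6000 nM to 22000 nM, allowing for a single precedent and the scatter of the measurement.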

Compound 4, half-maximal inhibitory concentration: 14400 nM
For compound 4 the middle estimate is 1.3-fold (0.12 log units) below the measured one; measured number inside the range.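

In this assay, bromo in place of chloro on an aromatic carbon gives a 1.2-fold lower number from compound 3 to compound 4 (0.06 log units; within the scatter), and the step on this core agrees with the one on the core of compound 1: the same change on two cores in this assay, a 1.5-fold lower number (0.17 log units; within the scatter) from compound 1 to compound 2 and a 1.2-fold lower number (0.06 log units; within the scatter) from compound 3 to compound 4, 1.3-fold (0.11 log units) apart, within the scatter of two such steps. Across these two cores the exchange therefore carries over as a step that stays within the scatter each time, and a value measured for a chloro compound in this pair of cores is a fair guide to its bromo partner. This does not show that the exchange itself has any effect on the number, and two cores cannot establish that the same would hold on a third core.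

The compounds shown carry only chloro or bromo at this aromatic carbon, so it remains open whether fluoro, methoxy, an amine or a carboxylic acid there would give a step beyond the scatter. The phenyl group is also the same throughout, which leaves open what a substituted phenyl or a pyridine in its place would give.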